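The source may hold more compounds than are shown below. What is called first, only, known or untested is meant among the compounds shown, and "the series" means these compounds.

Measured compounds:
compound 1, `OC[C@H]1O[C@@H](n2cnc3c(NCc4ccccc4)nccc32)C[C@@H]1O`: 15%
compound 2, `CCCCCCNc1[nH]ccc2ncnc1-2`: 53%

In a functional assay (Homo sapiens) for inhibition of Nucleic Acid, tested at 100 uM (on this read-out higher numbers stand for more inhibition at the one concentration tested (going by the name of the read-out) and lower numbers for less inhibition), compound 1 gives 15%, the lower of the two numbers recorded. Compound 2 stands in this assay at 53%, a figure beyond the scatter above that of compound 1; the two compounds differ in more than one place, so their values are simply two separate readings. Compound 3, `[N-]=[N+]=Nc1nccc2c1ncn2[C@H]1C[C@H](O)[C@@H](CO)O1`, keeps the rest of compound 1 and differs from it at one place: azido in place of benzylamino on an aromatic carbon. Within the data shown here, no pair of measured compounds shows what such a change does, so no size for this step is known from the data. The expected step from compound 1 to compound 3 in this assay is no change at the digits printed from compound 1 to compound 3 (within the scatter), which is meant as no change beyond the scatter. Compound 3 is therefore expected to show 15% in this assay, within a range from 0% to 40%.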

Compound 3, a percentage reported as inhibition, at one concentration (the size of the read-out at that concentration, not a potency): 4%
The estimate for compound 3 lay 11 percentage points above the measured number, within the range that was stated.
By their numbers in this assay, from the lowest: compound 3; then compound 1; then compound 2.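

With azido in place of benzylamino on an aromatic carbon next to the ring nitrogen, this assay records a number 11 percentage points lower from compound 1 to compound 3 (beyond the scatter). This gives the first measured size for a change at this position and shows that the reading here depends on the group the position carries, although a single step cannot separate the loss of the six-membered aromatic ring of carbon only from the loss of the hydrogen-bond donor or the arrival of azido itself. Nothing measured here explains the fall in the number. The compounds shown leave open whether a plain amine or a methoxy group at this position would read nearer to benzylamino or to azido. They also leave open how any such group would behave on the core of compound 2, which differs from compound 1 in more than one place.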